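The compounds below may be only part of what the source reports. "The series", "measured", "known", "first", "only" and "open" are said of these compounds alone.

Of the compounds shown here, two have been measured in a functional assay on MGC-803 cells (Homo sapiens) for antiproliferative activity, read by MTT assay, with a stated time of 72 h; on this read-out lower numbers stand for stronger inhibition and higher numbers for weaker inhibition. Compound 1, `CCCSc1nc(N/N=C/c2cccnc2)c2nnn(Cc3ccccc3)c2n1`, gives 38100 nM in this assay. Compound 2, `CCCSc1nc(N/N=C(\C)c2ccccc2O)c2nnn(Cc3ccc(O)cc3)c2n1`, gives 7680 nM in this assay, a lower number than that of compound 1; the two share a core but differ in more than one place, so no single change can be read from that pair. Of the two numbers, compound 1 stands at the higher one.

Compound 3, `CCCSc1nc(N/N=C/c2ccc(Br)cc2)c2nnn(Cc3ccccc3)c2n1`, has not yet been measured. It differs from compound 1 in one place: 4-bromophenyl in place of pyridin-3-yl on a carbon with a double bond to nitrogen. Within the data shown here, no measured pair shows what this exchange does on its own, so there is little to lean on. Compound 3 is therefore expected to stay near compound 1, with a step of a 1.5-fold lower number from compound 1 to compound 3 (0.18 log units; within the scatter) that could fall within the scatter in either direction. The estimate for compound 3 is 25000 nM, within a range from 8000 nM to 80000 nM.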

Compound 3, half-maximal inhibitory concentration: 34900 nM
Compound 3: the middle estimate sits 1.4-fold (0.14 log units) below what was measured, and the stated range covers the measured number.
By their numbers in this assay, from the lowest: compound 2; then compounds 3 and 1 (each within the scatter of the next).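

Among these compounds, exchanging pyridin-3-yl for 4-bromophenyl on the carbon with a double bond to nitrogen gives a 1.1-fold lower number from compound 1 to compound 3 (0.04 log units; within the scatter) in this assay, the only comparison so far in which just one place changes. A ring with a hydrogen-bond acceptor leaves and a carbon-only ring carrying bromine enters, yet compound 1 and compound 3 cannot be told apart on this read-out, so this exchange at this position leaves the number where it was. Nothing measured here offers an explanation for that outcome.

As far as these compounds go, only these two aromatic rings have been compared at this position, so it remains open whether a phenyl ring carrying a carboxylic acid or an amine would behave the same way. From the compounds shown here alone, compound 2 differs from compound 1 in more than one place, so the source of its lower number also remains open.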